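Acid dissociation in a quinoline-diamine series

The source may report more compounds than this note shows. Statements on the series, on what has been measured and on what is new or still open speak of the compounds shown alone.

Measured so far:
compound 1, `Fc1ccc(-c2ccc3c(NCCCNCc4ccco4)ccnc3c2)cc1`, 9.47
compound 2, `COc1cccc(CNCCCNc2ccnc3cc(-c4ccc(F)cc4)ccc23)c1O`, 9.47
compound 3, `Fc1ccc(Cc2ccc3c(NCCCNCc4ccco4)ccnc3c2)cc1`, 9.47

In a physicochemical assay for acid dissociation, compound 1, compound 2 and compound 3 lie level at the digits given. The change from compound 1 to compound 2 is 2-hydroxy-3-methoxyphenyl in place of furan-2-yl on a saturated chain carbon bound to an amine nitrogen; its step, no change at the digits printed from compound 1 to compound 2 (within the scatter), is within the scatter. The cores of compound 1 and compound 3 differ by 4-fluorobenzyl in place of 4-fluorophenyl on an aromatic carbon, and the step of no change at the digits printed from compound 1 to compound 3 (within the scatter) is likewise within the scatter.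

Compound 4, `COc1cccc(CNCCCNc2ccnc3cc(Cc4ccc(F)cc4)ccc23)c1O`, is not yet measured. It differs from compound 3 by 2-hydroxy-3-methoxyphenyl in place of furan-2-yl on a saturated chain carbon bound to an amine nitrogen, the same change as from compound 1 to compound 2, at the same place. Because no change at the digits printed from compound 1 to compound 2 (within the scatter) left the value unchanged, the step from compound 3 to compound 4 is expected to be no change at the digits printed from compound 3 to compound 4 (within the scatter), also flat. For compound 4 in this assay the estimate is therefore 9.47, from 9.1 to 9.8.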

Compound 4, acid dissociation constant: 9.47
Compound 4: the middle estimate sits on the measured number at the digits printed; low and high end bracket the measured number.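

In this assay, 2-hydroxy-3-methoxyphenyl in place of furan-2-yl gives no change at the digits printed from compound 3 to compound 4 (within the scatter), as flat as no change at the digits printed from compound 1 to compound 2 (within the scatter), so this change carries across these two cores without a visible step. The other change in the set, 4-fluorobenzyl in place of 4-fluorophenyl, reads the same on the second pair, with no change at the digits printed from compound 2 to compound 4 (within the scatter). Among the compounds shown here, this shows only that a flat step stayed flat on two cores, not how a step of real size would carry or that the pattern extends further, and no information at hand bears on why the values are level.

Open, from the compounds shown here alone, is whether a carboxylic acid or an amine in place of furan-2-yl, on a saturated chain carbon bound to an amine nitrogen, would also stay level in this assay. Going by these compounds, a longer chain on the shared core is equally open.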